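The source may report more compounds than this note shows. Statements on the series, on what has been measured and on what is new or still open speak of the compounds shown alone.

In an in vitro functional assay on HEK293-A cells for antagonist activity at metabotropic glutamate receptor 5 (Rattus norvegicus), read by calcium flux (on this read-out higher numbers stand for weaker inhibition and lower numbers for stronger inhibition), compound 1 `COc1ccccc1C(=O)Nc1cccc(NC(=O)c2ccc(Cl)c(Cl)c2)c1` gives > 30000 nM, which is a limit of the assay rather than a number. Compound 2 `COc1ccccc1C(=O)Nc1cccc(NC(=O)c2cccc(F)c2)c1` gives 6480 nM in this assay. Compound 3 `COc1ccccc1C(=O)Nc1cccc(NC(=O)C2CC2)c1` gives > 30000 nM in this assay, again a limit and not a number.

Compound 3 thus sits at the limit of > 30000 nM in this assay, at which 2 of the 3 values shown sit, the weakest end the read-out can report. Compound 4 `COc1ccccc1C(=O)Nc1cccc(NC(=O)C(C)C)c1` differs from it by isopropyl in place of cyclopropyl on a carbonyl carbon. Among the compounds with values here, no measured step swaps these two groups. The nearest guide is an at least 4.6-fold higher number from compound 2 to compound 3 (0.66 log units; beyond the scatter), which already leaves the cyclopropyl amide at the limit, while a step that the two limits leave unreadable from compound 1 to compound 3 cannot be sized. Compound 4 is therefore expected to remain at the limit, a step of a number no higher from compound 3 to compound 4 (the limit leaves the size open). The estimate for compound 4 is 30000 nM, between 10000 nM and 100000 nM.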

Compound 4, half-maximal inhibitory concentration: > 30000 nM
Compound 4: no number, only a limit; the forecaster's own chance of this, stated with the estimate: 85%; the middle value sits exactly at the limit.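

For compound 4 the read-out gives only a limit, not a number, and it joins the compounds already there: the limit of > 30000 nM in this assay, at which 3 of the 4 values shown sit. Isopropyl in place of 3-fluorophenyl gives an at least 4.6-fold higher number from compound 2 to compound 4 (0.66 log units; beyond the scatter), so the loss seen with cyclopropyl does not depend on a three-membered ring at this position. The steps from compound 1 and from compound 3 to compound 4 cannot be read, as both ends are limits.

Still open, from the compounds shown here alone, is whether a plain phenyl or a 3-chlorophenyl on this carbonyl carbon would give a measurable number. Also open, going by these compounds, is how far compound 3 and compound 4 lie beyond the limit.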